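Methoxy to Hydroxy: What Compound 3 Might Show

The compounds below may be only part of what the source reports. "The series", "measured", "known", "first", "only" and "open" are said of these compounds alone.

Measured compounds:
Compound 1, `COc1cc(-c2nn(-c3ccc(NC(=O)c4ccc(Cl)c(Cl)c4)cc3)cc2-c2ccncc2)ccc1Cl`: 13000 nM
Compound 2, `COc1cc(-c2nn(-c3ccc(NC(=O)c4cc(Cl)cc(Cl)c4)cc3)cc2-c2ccncc2)ccc1Cl`: > 20000 nM

In a functional assay on A375P cells (Homo sapiens) for antiproliferative activity, read by MTT assay, with a stated time of 48 h (on this read-out higher numbers stand for weaker inhibition and lower numbers for stronger inhibition), compound 1 gives 13000 nM. For compound 2 the assay reports only a limit, > 20000 nM. Compound 1 thus holds the only number shown; the other entry is the limit of > 20000 nM in this assay, at which 1 of the 2 values shown sits.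

For the measured compounds named here, the single measured step, an at least 1.5-fold higher number from compound 1 to compound 2 (0.18 log units; that floor lies within the scatter), concerns the dichlorophenyl group on the carbonyl carbon and its floor lies within the scatter. Compound 3, `O=C(Nc1ccc(-n2cc(-c3ccncc3)c(-c3ccc(Cl)c(O)c3)n2)cc1)c1ccc(Cl)c(Cl)c1`, differs from compound 1 at another place: hydrogen in place of methyl on an oxygen on an aromatic ring. Going by the values given here, no measured step touches that oxygen, so the data give no direction for this change. The expectation is therefore a number near that of compound 1, and the expected step is no change at the digits printed from compound 1 to compound 3 (within the scatter), within the scatter. Compound 3 is estimated at 13000 nM, with a range from 4000 nM to 40000 nM.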

Compound 3, half-maximal inhibitory concentration: 6700 nM
Compound 3: middle estimate off by 1.9-fold (0.29 log units), on the high side, and the stated range covers the measured number.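

In this assay the change from methoxy to hydroxy gives a 1.9-fold lower number from compound 1 to compound 3 (0.29 log units; within the scatter) on the 4-chloro-3-methoxyphenyl group, the first step shown at this oxygen. The step lies within the usual scatter of repeated measurements, so the methyl on this oxygen can give way to a hydrogen without a change that these data can tell from noise, and neither compound can be ranked above the other. Nothing available here bears on why the two compounds read as they do.

On these data alone, whether a longer chain on this oxygen, such as ethoxy, or an amine in place of the hydroxy would give a step beyond the scatter stays open. Also open, as far as these compounds go, is how the hydroxy would read together with the 3,5-dichlorophenyl group of compound 2.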